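Removing the amide-bearing side chain from compound 3

The source may hold more compounds than are shown below. What is called first, only, known or untested is meant among the compounds shown, and "the series" means these compounds.

Measured compounds and their values in a physicochemical assay for lipophilicity, read by HPLC, measured as chromatographic lipophilicity, at pH 7.4; on this read-out higher numbers stand for higher lipophilicity and lower numbers for lower lipophilicity:
compound 1, `CCC(=O)NCCCO[C@H]1[C@H](C)[C@@H](O[C@@H]2O[C@H](C)C[C@H](N(C)C)[C@H]2O)[C@](C)(O)C[C@@H](C)CN(C)[C@H](C)[C@@H](O)[C@](C)(O)[C@@H](CC)OC(=O)[C@@H]1C`, 1.6
compound 2, `CCCCCCCC(=O)NCCCO[C@H]1[C@H](C)O[C@@H](O[C@H]2[C@H](C)[C@@H](O[C@@H]3O[C@H](C)C[C@H](N(C)C)[C@H]3O)[C@](C)(O)C[C@@H](C)CN(C)[C@H](C)[C@@H](O)[C@](C)(O)[C@@H](CC)OC(=O)[C@@H]2C)C[C@@]1(C)OC`, 4.1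
compound 3, `CC[C@H]1OC(=O)[C@H](C)[C@@H](OCCCNC(=O)COC)[C@H](C)[C@@H](O[C@@H]2O[C@H](C)C[C@H](N(C)C)[C@H]2O)[C@](C)(O)C[C@@H](C)CN(C)[C@H](C)[C@@H](O)[C@]1(C)O`, 1.4

Compound 3 stands lowest of the three numbers in this assay. Its nearest neighbour is compound 1, and that pair differs by a number 0.20 log units lower from compound 1 to compound 3 (within the scatter), which is within the scatter. Among the compounds with values here, compound 2 lies far above compound 3, but its structure differs from compound 3 in more than one place, so no single step connects them.

Compound 4, `CC[C@H]1OC(=O)[C@H](C)[C@@H](O)[C@H](C)[C@@H](O[C@@H]2O[C@H](C)C[C@H](N(C)C)[C@H]2O)[C@](C)(O)C[C@@H](C)CN(C)[C@H](C)[C@@H](O)[C@]1(C)O`, differs from compound 3 in this way: hydrogen in place of 3-(((methoxymethyl)carbonyl)amino)propyl on an oxygen on a saturated carbon. Within the data shown here, no measured step removes the whole chain at this position; the only measured step, from compound 1 to compound 3, exchanges a group on the end of the chain and is within the scatter, so it bears on this change only loosely. The chain that leaves carries six carbons together with an amide and a methoxy group, so a downward step in this assay is expected for compound 4, of about a number 0.50 log units lower from compound 3 to compound 4 (beyond the scatter). Compound 4 is therefore estimated at 0.9, with a range from 0.3 to 1.5.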

Compound 4, distribution coefficient: 1.35
For compound 4 the middle estimate is 0.45 log units below the measured one; the range from low to high includes it.
By their numbers in this assay, from the lowest: compounds 4, 3 and 1 (each within the scatter of the next); then compound 2.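

In this assay, replacing 3-(((methoxymethyl)carbonyl)amino)propyl with hydrogen on the oxygen gives a number 0.05 log units lower from compound 3 to compound 4 (within the scatter), and replacing 3-(propanoylamino)propyl with hydrogen gives a number 0.25 log units lower from compound 1 to compound 4 (within the scatter). The earlier step exchanged only the end of the chain, whereas these two take away the whole chain, and at this position neither step leaves the scatter. With either chain on this oxygen or only the hydroxy of compound 4, the read-out therefore cannot tell the three compounds apart, and nothing shown offers an explanation for this.

On these data alone, it remains open whether a much longer chain, or an amine or a carboxylic acid at the end of the propyl chain, would also stay within the scatter of compound 4. Compound 2 differs from these compounds in more than one place, so it cannot settle that question.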